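The source may hold more compounds than are shown below. What is called first, only, known or untested is meant among the compounds shown, and "the series" means these compounds.

For the measured compounds named here, in an assay on mitochondria from L6 cells (Rattus norvegicus) for activation, with a stated time of 90 min (on this read-out higher numbers stand for an effect only at larger amounts of compound and lower numbers for an effect already at smaller amounts), compound 2 `FC(F)(F)c1cccc(Nc2nc3nonc3nc2Nc2cccc(C(F)(F)F)c2)c1` gives 700 nM, the only actual number among the three values shown. Compound 1 `Fc1cc(C(F)(F)F)ccc1Nc1nc2nonc2nc1Nc1ccc(C(F)(F)F)cc1F` gives only a limit in this assay, < 1000 nM. Compound 3 `Fc1cc(Br)ccc1Nc1nc2nonc2nc1Nc1ccc(Br)cc1F` likewise gives only a limit in this assay, < 3000 nM. Compound 4 `Fc1ccccc1Nc1nc2nonc2nc1Nc1cccc(C(F)(F)F)c1` has not yet been measured; it differs from compound 2 by 2-fluorophenyl in place of 3-(trifluoromethyl)phenyl on a nitrogen on an aromatic ring. Going by the values given here, no step between two measured compounds is available to weigh a change of this kind, so the expectation rests on compound 2 alone. The step expected in this assay is a 2.1-fold higher number from compound 2 to compound 4 (0.33 log units; beyond the scatter), a modest loss, likely no larger than the usual scatter or only just beyond it. Compound 4 is therefore estimated at 1500 nM, with a range from 500 nM to 5000 nM.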

Compound 4, half-maximal effective concentration: < 1000 nM
Compound 4 was reported as a limit (the forecaster's own chance of this, stated with the estimate: 30%); middle value at least 1.5-fold (0.17 log units) from the limit.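

In this assay, for the compounds shown here, compound 4 gives only a limit, < 1000 nM, so no step between compound 2 and compound 4 can be read. The compounds shown leave open how much 2-fluorophenyl in place of 3-(trifluoromethyl)phenyl changes the read-out, or in which direction.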